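Cytotoxicity notes on a shared amide core: furan variation

The source may hold more compounds than are shown below. What is called first, only, known or untested is meant among the compounds shown, and "the series" means these compounds.

The series shares one core, seen in compound 1 `Cc1ccsc1C(=O)N1CCCn2nc(C(=O)Nc3ccccc3)cc2C1`, compound 2 `O=C(Nc1ccccc1)c1cc2n(n1)CCCN(C(=O)c1occc1Cl)C2`, compound 3 `Cc1c(C(=O)N2CCCn3nc(C(=O)Nc4ccccc4)cc3C2)oc2ccccc12` and compound 4 `Cc1cc(C)c(C(=O)N2CCCn3nc(C(=O)Nc4ccccc4)cc3C2)o1`, and differs only in the acyl group on the ring nitrogen. The readout followed here is an ADME assay on BEAS-2B cells (Homo sapiens) for cytotoxicity, read by fluorescence, with a stated time of 48 h; a higher number here means that more compound is tolerated, a lower number that less compound is tolerated. In this assay compound 1 gives "not determined" (no result reported) and compound 3 gives "not determined" (no result reported). Among the compounds with values here, compound 2 is the only member with a number: in this assay compound 2 gives 30000 nM. With a single measured value, compound 2 cannot be placed against any other member of the series; it simply marks the one known point.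

Compound 4 is not yet measured. The change from compound 2 to compound 4 is 3,5-dimethylfuran-2-yl in place of 3-chlorofuran-2-yl on a carbonyl carbon. Within the data shown here, no pair of measured compounds shows a step of this kind, so there is no measured precedent for the size or direction of the effect. Given that compound 2 gives 30000 nM and nothing else in the series constrains the outcome, the expectation for compound 4 is a step of no change at the digits printed from compound 2 to compound 4 (within the scatter) that stays within the scatter, with no direction favoured. Compound 4 is therefore estimated at 30000 nM, with a range from 10000 nM to 90000 nM.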

Compound 4, half-maximal cytotoxic concentration: 2600 nM
For compound 4 the middle estimate is 12-fold (1.06 log units) above the measured one, outside the stated range (below it).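

In this assay, within the data shown here, 3,5-dimethylfuran-2-yl in place of 3-chlorofuran-2-yl on a carbonyl carbon gives a 12-fold lower number from compound 2 to compound 4 (1.06 log units; beyond the scatter) in the only step that can be read. This shows that the acyl group on the ring nitrogen is not a silent position: a change confined to the furan substituents moves the result beyond the scatter, with less compound tolerated for the dimethylfuran, and compound 2 now stands as the upper end of a measured step rather than as an isolated point. No measurement on hand accounts for this step.

Compounds 1 and 3 carry no number, so any steps involving them cannot be read, and the thiophene and benzofuran acyl groups remain unplaced. Among these compounds, the single exchange removes the chlorine and brings in both methyl groups at once, so their separate contributions stay open, as does the result for an unsubstituted furan-2-yl or for a furan carrying a carboxylic acid on the same carbonyl carbon.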